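The source may report more compounds than this note shows. Statements on the series, on what has been measured and on what is new or still open speak of the compounds shown alone.

Measured so far:
- compound 1, `COCc1cc(COC)c(C(=O)/C=C/c2ccc(OC)cc2)c(OC)c1`: > 250000 nM
- compound 2, `C=CCOc1cc(OC)c(C(=O)/C=C/Cc2ccccc2)c(OCC=C)c1`: 14800 nM
- compound 3, `C=CCOc1cc(/C=C/C(=O)c2c(O)cc(O)cc2OC)cc(OCC=C)c1Br`: 11500 nM

In a toxicity assay on cells (Macrophage, Mus musculus, strain BALB/c) for cytotoxicity, read by MTT assay (on this read-out lower numbers stand for stronger inhibition and higher numbers for weaker inhibition), compound 1 gives only a limit, > 250000 nM, so its value is a bound of the assay and not a number; this is the limit noted as the limit of > 250000 nM in this assay, at which 1 of the 3 values shown sits. In this assay compound 2 gives 14800 nM, the highest of the two numbers shown. In this assay compound 3 gives 11500 nM, the nearest value to compound 2 and within the usual scatter of it, so the two are not ordered.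

The unmeasured compound 4, `C=CCOc1cc(OC)c(C(=O)/C=C/c2cccc(OC)c2)c(OCC=C)c1`, differs from compound 2 in one place: 3-methoxyphenyl in place of benzyl on a double-bonded chain carbon bound to a double-bonded chain carbon. Going by the values given here, no measured step isolates such a change, so the direction rests on the three values alone. With compound 1, which carries a methoxyphenyl group and sits at the limit, the expectation is a modest move towards weaker cytotoxicity, or none beyond the scatter.

Compound 4 is expected to give 25000 nM in this assay, within 8000 nM to 100000 nM. The step expected is a 1.7-fold higher number from compound 2 to compound 4 (0.23 log units; within the scatter).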

Compound 4, half-maximal inhibitory concentration: 13100 nM
The estimate for compound 4 lay 1.9-fold (0.28 log units) above the measured number; the measured number falls inside the stated range.
By their numbers in this assay, from the lowest: compounds 3, 4 and 2 (each within the scatter of the next). At a limit, above all of these: compound 1.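

In this assay, going by these compounds alone, 3-methoxyphenyl in place of benzyl on a double-bonded chain carbon bound to a double-bonded chain carbon gives a 1.1-fold lower number from compound 2 to compound 4 (0.05 log units; within the scatter), the first step that isolates a change in one place. The entering group brings an oxygen and a hydrogen-bond acceptor and keeps the six-membered aromatic ring, yet compound 4 and compound 2 cannot be told apart in this read-out at this place. Nothing measured here bears on why this step is so small.

On these data alone, it remains open whether other groups at this place would also leave the read-out within the scatter, such as an amine, a carboxylic acid or a longer chain in place of benzyl. As far as these compounds go, with a single replacement to read, the separate contribution of the methoxy group also remains open, and an unsubstituted phenyl would address it.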